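Amino in place of carboxy in compound 3

The source may report more compounds than this note shows. Statements on the series, on what has been measured and on what is new or still open speak of the compounds shown alone.

Measured so far in a functional assay on U-937 cells (Homo sapiens) for antagonist activity, read by calcium flux (a lower number here means a stronger inhibitor, a higher number a weaker inhibitor), for three compounds:
- compound 1 `COc1ccc(CCCCCCCCOc2ccc(C[S+]([O-])c3ccccc3)nc2/C=C/C(=O)O)cc1` gives 280 nM
- compound 2 `CCCCCCCCCCCCOc1ccc(COc2cccc(C(=O)O)c2)nc1/C=C/C(=O)O` gives 580 nM
- compound 3 `COc1ccc(CCCCCCCCOc2ccc(CSc3cccc(C(=O)O)c3)nc2/C=C/C(=O)O)cc1` gives 390 nM

Compound 3 at 390 nM lies within the scatter of both compound 1 and compound 2. Compound 4 `COc1ccc(CCCCCCCCOc2ccc(CSc3cccc(N)c3)nc2/C=C/C(=O)O)cc1` differs from compound 3 in one place (amino in place of carboxy on an aromatic carbon) and carries amino in place of carboxy on an aromatic carbon. Going by the values given here, no measured pair makes exactly this swap, so the evidence is indirect. The closest guide is the step of a 1.4-fold higher number from compound 1 to compound 3 (0.14 log units; within the scatter) and it stays small. Compound 1 has no carboxy on that ring, and compound 1 still gives 280 nM in this assay as its number. On that basis, no step beyond the scatter is expected, although the effect of an amino group itself has not been measured. The estimated step is a 1.0-fold higher number from compound 3 to compound 4 (0.01 log units; within the scatter) and it comes with wide uncertainty. Compound 4 is estimated at 400 nM with 130 nM to 1200 nM as the expected range.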

Compound 4, half-maximal inhibitory concentration: 54 nM
Compound 4: the middle estimate sits 7.4-fold (0.87 log units) above what was measured; the measured number lies below the stated range.
By their numbers in this assay, from the lowest: compound 4; then compounds 1, 3 and 2 (each within the scatter of the next, the first and the last beyond it).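

In this assay, the ring carrying the 3-carboxyphenyl group had not yet shown that this position matters, but the change to 3-aminophenyl gives a 7.2-fold lower number from compound 3 to compound 4 (0.86 log units; beyond the scatter), so the group on this aromatic carbon can clearly move the number. The second comparison, a 5.2-fold lower number from compound 1 to compound 4 (0.71 log units; beyond the scatter), points the same way, but it also differs in the oxygen on sulfur, so it cannot be read as the effect of the amino group alone. No available evidence gives a reason for either step.

The compounds shown leave open whether the difference comes from having amino or from losing carboxy, and an unsubstituted phenyl on the same sulfanyl link would separate the two. A hydroxy or methylamino group at this position would show how closely the result depends on amino itself.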